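A few compounds are considered here, and "the series" means these few. Any claim that something is new, unique, unknown or untested is made for them only; others in the source may bear on it.

Measured so far:
- Compound 1 `Cn1cncc1/C=N/Nc1ccnc2cc(Cl)ccc12`: 73.8 uM
- Compound 2 `Oc1cc(/C=N/Nc2ccnc3cc(Cl)ccc23)ccc1CN1CCCC1`: 152 uM

In a functional assay on KB cells (Homo sapiens) for cytotoxicity (on this read-out lower numbers stand for an effect already at smaller amounts and higher numbers for an effect only at larger amounts of compound), compound 2 gives 152 uM, the higher of the two numbers in the series. Compound 1 sits lower at 73.8 uM, and the gap between the two lies just beyond the scatter. The two compounds differ in more than one place, so their gap does not isolate any single structural change.

Compound 3 `Clc1ccc2c(N/N=C/c3ccc(CN4CCCC4)cc3)ccnc2c1` is still to be measured in this assay. It departs from compound 2 at one place: hydrogen in place of hydroxy on an aromatic carbon. In words, this puts hydrogen in place of hydroxy on an aromatic carbon, ortho to a (pyrrolidin-1-yl)methyl group.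

Among the compounds with values here, no measured pair shows this change, so the direction is a weak call. A modest move towards the lower number is the working expectation, and it may not clear the scatter. The estimated size is a 1.5-fold lower number from compound 2 to compound 3 (0.18 log units; within the scatter). For compound 3 the expected value is 100 uM, with an estimated range of 35 uM to 280 uM.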

Compound 3, concentration for half-maximal effect: 19.5 uM
For compound 3 the middle estimate is 5.1-fold (0.71 log units) above the measured one, outside the stated range (below it).
By their numbers in this assay, from the lowest: compound 3; then compound 1; then compound 2.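

In this assay, within the data shown here, hydrogen in place of hydroxy on an aromatic carbon, ortho to a (pyrrolidin-1-yl)methyl group, gives a 7.8-fold lower number from compound 2 to compound 3 (0.89 log units; beyond the scatter) and so provides the first single-place step, one that lies beyond the scatter. This shows that the read-out is sensitive to what sits at this position, with the hydrogen form showing its effect at smaller amounts than the hydroxy form. The data offer no measurement that bears on the reason for this step.

With only hydrogen and hydroxy shown at this position, it remains open whether a methoxy group or a fluorine atom on the same aromatic carbon would give a number closer to that of compound 2 or to that of compound 3. Going by these compounds, it also remains open whether the step keeps its direction and size when the (pyrrolidin-1-yl)methyl group gives way to a dimethylaminomethyl group, and compound 1, which differs from the other two in more than one place, cannot settle either question.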